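The compounds below may be only part of what the source reports. "The series", "measured", "known", "first", "only" and "open" are said of these compounds alone.

Compound 1 `CCNc1cc(-c2ccc(NC(=O)Nc3c(C)cccc3C)cc2C)ccn1`: 7920 nM
Compound 2 `CCNc1cc(-c2ccc(NC(=O)Nc3cccc4ccccc34)cc2C(F)(F)F)ccn1`: 16300 nM

In a functional assay on MCF7 cells (Homo sapiens) for cytotoxicity, read by MTT assay, with a stated time of 24 h (on this read-out higher numbers stand for weaker inhibition and lower numbers for stronger inhibition), compound 2 gives 16300 nM, the higher of the two numbers and so the weaker inhibition. Its gap to compound 1 lies beyond the scatter. Compound 3 `CCNc1cc(-c2ccc(NC(=O)Nc3c(C)cccc3C)cc2C(F)(F)F)ccn1` has not yet been measured. It differs from compound 2 in one place: 2,6-dimethylphenyl in place of naphthalen-1-yl on an amide-type nitrogen, with 2,6-dimethylphenyl in place of naphthalen-1-yl on an amide-type nitrogen. For the measured compounds named here, no step between measured compounds shows this change on its own, so the evidence is thin. Going by the values given here, the only guide is compound 1, which also carries 2,6-dimethylphenyl and gives 7920 nM. A modest fall in the number is therefore expected, near the edge of the scatter. The estimated change is a 1.6-fold lower number from compound 2 to compound 3 (0.19 log units; within the scatter). The estimate for compound 3 is 10500 nM, with an expected range of 5000 nM to 22000 nM.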

Compound 3, half-maximal inhibitory concentration: 6950 nM
Estimate against measurement, compound 3: 1.5-fold (0.18 log units) above, within the range that was stated.
By their numbers in this assay, from the lowest: compounds 3 and 1 (each within the scatter of the next); then compound 2.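

In this assay, for the compounds shown here, the step of a 2.3-fold lower number from compound 2 to compound 3 (0.37 log units; beyond the scatter) is the first direct reading of 2,6-dimethylphenyl in place of naphthalen-1-yl on an amide-type nitrogen, and it lies beyond the scatter with trifluoromethyl held constant elsewhere in the molecule. Trifluoromethyl in place of methyl on an aromatic carbon, seen in the step of a 1.1-fold lower number from compound 1 to compound 3 (0.06 log units; within the scatter), stays within the scatter, so with 2,6-dimethylphenyl on that nitrogen the two groups cannot be told apart in this assay. Nothing in the data bears on the reason for either step.

Going by these compounds, it remains open whether the swap of naphthalen-1-yl for 2,6-dimethylphenyl reads the same with methyl on that aromatic carbon. On these data alone, how a cyclohexyl group or a butyl chain would read on the amide-type nitrogen is also open.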